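Two Bulky Aryl Triazoles at the Limit, One Still Open

The source may hold more compounds than are shown below. What is called first, only, known or untested is meant among the compounds shown, and "the series" means these compounds.

Compound 1 `C/C(=C\CC/C(C)=C/CC[C@@H]1[C@@]2(C)CCC(=O)C(C)(C)[C@H]2CC[C@@]1(C)O)CC/C=C(\C)C(=O)OCc1cn(-c2ccccc2C(F)(F)F)nn1`: > 150000 nM
Compound 2 `C/C(=C\CC/C(C)=C/CC[C@@H]1[C@@]2(C)CCC(=O)C(C)(C)[C@H]2CC[C@@]1(C)O)CC/C=C(\C)C(=O)OCc1cn(-c2ccccc2Br)nn1`: > 150000 nM

In a functional assay on MDA-MB-231 cells (Homo sapiens) for antiproliferative activity, read by MTT assay, with a stated time of 48 h (a higher number here means a weaker inhibitor, a lower number a stronger inhibitor), compound 1 gives > 150000 nM, which is a limit of the assay and not a number. Compound 2 gives > 150000 nM, and this too is a limit. Compound 1 therefore stands level with the only other compound measured, and the data shown stop at the limit of > 150000 nM in this assay, at which 2 of the 2 values shown sit.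

Compound 3 `C/C(=C\CC/C(C)=C/CC[C@@H]1[C@@]2(C)CCC(=O)C(C)(C)[C@H]2CC[C@@]1(C)O)CC/C=C(\C)C(=O)OCc1cn(-c2cccc(F)c2)nn1` keeps the shared core of compound 1 and changes one group: 3-fluorophenyl in place of 2-(trifluoromethyl)phenyl on an aromatic nitrogen of a five-membered aromatic ring with 3 nitrogen (3-fluorophenyl in place of 2-(trifluoromethyl)phenyl on an aromatic nitrogen). Going by the values given here, the one measured step that bears on this change is a step that the two limits leave unreadable from compound 1 to compound 2, which also alters a substituent on the aromatic ring. Since a step that the two limits leave unreadable from compound 1 to compound 2 has no readable size, no step beyond the scatter is expected in this assay, and no direction can be named. The estimated change is a number no higher from compound 1 to compound 3 (the limit leaves the size open). Compound 3 is expected to lie close to that same limit, at an estimated 150000 nM, with a range of 50000 nM to 300000 nM.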

Compound 3, half-maximal inhibitory concentration: 144000 nM
Beside the measured number, compound 3's estimate is 1.0-fold (0.02 log units) above it; measured number inside the range.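

In this assay compound 3 gives 144000 nM, an actual number. It is the only compound shown so far that does not stop at a limit. Putting 3-fluorophenyl in place of 2-(trifluoromethyl)phenyl on the aromatic nitrogen gives an at least 1.0-fold lower number from compound 1 to compound 3 (0.01 log units; that floor lies within the scatter), and putting it in place of 2-bromophenyl gives an at least 1.0-fold lower number from compound 2 to compound 3 (0.01 log units; that floor lies within the scatter). These floors show no gain beyond the scatter, so this change places one value within reach of measurement but does not separate it clearly from the others, which remain at the top of the range: the limit of > 150000 nM in this assay, at which 2 of the 3 values shown sit.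

As far as these compounds go, how far compound 1 and compound 2 lie past their limits stays open, and the step between them cannot be read. Also open, from the compounds shown here alone, is whether an amine or a carboxylic acid in place of the fluorine of compound 3 would give a number clearly away from this one, which would show whether this position can move the value at all.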